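The compounds below may be only part of what the source reports. "The series", "measured", "known", "first", "only" and "open" are said of these compounds alone.

Two compounds in this set have a measured number. Compound 1 `CCCN(C)c1nc(C)nc2c(-c3c(C)cc(OC)cc3OC)c(C)nn12` gives 6.48 nM in an assay on cell membranes for displacement of a labelled ligand from corticotropin-releasing factor receptor 1 (Rattus norvegicus); a lower number here means a stronger inhibitor, a higher number a weaker inhibitor. Compound 2 `CCC(CC)Nc1nc(C)nc2c(-c3ccc(OC)cc3)c(C)nn12` gives 3.8 nM in this assay . These two numbers sit within the usual scatter of repeated measurements of each other, so compound 1 cannot be set apart from compound 2 on this evidence, and neither can be called the stronger binder.

Compound 3 `CCN(CC)c1nc(C)nc2c(-c3c(C)cc(OC)cc3OC)c(C)nn12` is derived from compound 1 by a single rearrangement: diethylamino in place of methyl(propyl)amino on an aromatic carbon. The two compounds contain the same atoms, joined differently; what leaves and what enters match each other in size and in their hydrogen-bonding groups. Among the measured compounds shown here, no measured pair in this set shows what such a rearrangement does here, so the expectation rests on the smallness of the change alone.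

The step is expected to be small, a 1.1-fold higher number from compound 1 to compound 3 (0.03 log units; within the scatter), with no firm direction and not beyond the scatter. Compound 3 is therefore expected to give about 7 nM in this assay , with a range from 3 nM to 16 nM.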

Compound 3, half-maximal inhibitory concentration: 1.2 nM
Estimate against measurement, compound 3: 5.8-fold (0.77 log units) above, outside the stated range (below it).
By their numbers in this assay, from the lowest: compound 3; then compounds 2 and 1 (each within the scatter of the next).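

In this assay, exchanging methyl(propyl)amino for diethylamino, on the aromatic carbon between two ring nitrogen atoms, gives a 5.4-fold lower number from compound 1 to compound 3 (0.73 log units; beyond the scatter). This position therefore tells apart two groups that contain the same atoms and match in size and hydrogen-bonding groups, so how those atoms are joined counts here, at least for this one pair on the core of compound 1. Nothing measured here accounts for the difference between these two amines.

The compounds shown leave open how far this sensitivity extends: dipropylamino, with a longer chain on both sides of the nitrogen, or pyrrolidine, with the two chains closed into a ring, would show whether the numbers keep moving as this group changes shape. Compound 2 differs from compound 3 in both its amine and its aromatic group, so it cannot show whether diethylamino would bring a similar step on a different aromatic group.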